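Methoxy in place of ethyl: a step expected inside the scatter

A few compounds are considered here, and "the series" means these few. Any claim that something is new, unique, unknown or untested is made for them only; others in the source may bear on it.

Compound 1 `CCc1cccc(NC(=O)N[C@H](C)c2ccccc2)c1` was tested in an ADME assay on the whole organism with Oryza sativa as the target, tested at 0.1 uM (on this read-out lower numbers stand for a stronger effect and higher numbers for a weaker effect at the one concentration tested), where compound 1 gives 97%. Compound 2 `CCc1cccc(NC(=O)N[C@@H](C)c2ccccc2)c1` gives 100%, and compound 3 `C[C@H](NC(=O)Nc1ccccc1C(C)(C)C)c1ccccc1` gives 101%; all three numbers lie within the usual scatter of one another, so none stands apart. Going by the values given here, the only measured step, a number 3 percentage points higher from compound 1 to compound 2 (within the scatter), reflects the fact that compounds 1 and 2 differ only in the configuration as drawn and says nothing about exchanging one group for another. The unmeasured compound 4 `COc1cccc(NC(=O)N[C@H](C)c2ccccc2)c1` differs from compound 1 by methoxy in place of ethyl on an aromatic carbon. Among the compounds with values here, no measured pair probes such a change, and every step seen stays within the scatter, so the step of a number 1 percentage points higher from compound 1 to compound 4 (within the scatter) is expected to be no larger. Compound 4 is therefore estimated to give 98%, between 88% and 106%.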

Compound 4, a percentage reported as activity, at one concentration (the size of the read-out at that concentration, not a potency): 104%
For compound 4 the middle estimate is 6 percentage points below the measured one; the range from low to high includes it.
By their numbers in this assay, from the lowest: compounds 1, 2, 3 and 4 (each within the scatter of the next).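

Exchanging ethyl for methoxy on an aromatic carbon is the first change of group among these compounds, and in this assay it gives a number 7 percentage points higher from compound 1 to compound 4 (within the scatter). At this position, then, adding a hydrogen-bond acceptor while keeping the same count of heavy atoms does not move the read-out beyond the usual scatter. Nothing at hand bears on this particular change. As far as these compounds go, whether an amine, a carboxylic acid or a longer chain at this place would move the number beyond the scatter stays open. So does how methoxy behaves with the configuration drawn in compound 2.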